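Benzyloxy Variation and Growth Inhibition in Prostate Cancer Cells

The source may hold more compounds than are shown below. What is called first, only, known or untested is meant among the compounds shown, and "the series" means these compounds.

Compound 2 `COc1cccc(OC)c1OCCNCCOc1ccccc1OCc1ccc(Cl)cc1` gives 14500 nM in a functional assay on PC-3 cells (Homo sapiens) for cytotoxicity, read by sulforhodamine B assay (a higher number here means a weaker inhibitor of growth, a lower number a stronger inhibitor of growth), the lowest number among the three measured. Compound 1 `COc1cccc(OC)c1OCCNCCOc1ccccc1OCc1cccc(Cl)c1` gives 20400 nM, and compound 3 `COc1cccc(OC)c1OCCNCCOc1ccccc1OCc1cccc(C)c1` gives 32300 nM. Compound 4 `COc1cccc(OC)c1OCCNCCOc1ccccc1OCc1cccc([N+](=O)[O-])c1` carries 3-nitrophenyl in place of 4-chlorophenyl on a saturated chain carbon bound to an oxygen on an aromatic ring. Among the compounds with values here, two measured steps bear on this change: the move a 1.4-fold lower number from compound 1 to compound 2 (0.15 log units; within the scatter) and the move a 2.2-fold higher number from compound 2 to compound 3 (0.35 log units; beyond the scatter). Both steps involve only the substituent on this phenyl ring, and neither moved the number far. He therefore expects the step from compound 2 to compound 4 to be small and probably towards a higher number, a 1.5-fold higher number from compound 2 to compound 4 (0.18 log units; within the scatter), with no certainty that it exceeds the scatter. His estimate for compound 4 is 22000 nM, within the range 10000 nM to 50000 nM.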

Compound 4, concentration for total growth inhibition: 38900 nM
Beside the measured number, compound 4's estimate is 1.8-fold (0.25 log units) below it, and the stated range covers the measured number.
By their numbers in this assay, from the lowest: compounds 2, 1, 3 and 4 (each within the scatter of the next, the first and the last beyond it).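

The 3-nitrophenyl group is a second replacement of 4-chlorophenyl at this position that moves beyond the scatter (a 2.7-fold higher number from compound 2 to compound 4 (0.43 log units; beyond the scatter)), after 3-methylphenyl. Nitro in place of methyl (a 1.2-fold higher number from compound 3 to compound 4 (0.08 log units; within the scatter)) and nitro in place of chloro (a 1.9-fold higher number from compound 1 to compound 4 (0.28 log units; within the scatter)) both stay within the scatter, so neither step separates the nitro group from the group it replaces. Only the 4-chlorophenyl compound stands apart from compound 3 and compound 4 in this assay.

As far as these compounds go, whether an amine or a carboxylic acid on this phenyl ring would give a lower or a higher number remains open. No outside data explain these differences.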